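The source may report more compounds than this note shows. Statements on the series, on what has been measured and on what is new or still open speak of the compounds shown alone.

Measured so far in a toxicity assay on Huh-7.5 cells (Homo sapiens) for inhibition, read by MTT assay, with a stated time of 96 h; a higher number here means that more compound is tolerated, a lower number that less compound is tolerated:
compound 1 `CN1CCN(Cc2ccc(NC(=O)c3ccc(OCCCCl)c(F)c3)cc2C(F)(F)F)CC1` gives 8800 nM
compound 2 `CN1CCN(Cc2ccc(NC(=O)c3ccc(OCCCCl)c(C(F)(F)F)c3)cc2C(F)(F)F)CC1` gives 13400 nM

Compound 2 stands level with compound 1 within the scatter, so these two numbers set no order between them. Compound 3 `CCC(=O)Nc1cc(C(=O)Nc2ccc(CN3CCN(C)CC3)c(C(F)(F)F)c2)ccc1OCCCCl` is the next step from compound 2. The change is propanoylamino in place of trifluoromethyl on an aromatic carbon and amounts to propanoylamino in place of trifluoromethyl on an aromatic carbon, ortho to a 3-chloropropoxy group.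

Within the data shown here, one measured step bears on this carbon, trifluoromethyl in place of fluoro, and it gives a 1.5-fold higher number from compound 1 to compound 2 (0.18 log units; within the scatter) as the whole of the evidence. No measured compound carries propanoylamino here, so the effect of this replacement has not been shown directly and the range has to stay wide. Going by compound 2 at 13400 nM and that one small step, no change beyond the scatter is expected in this assay in either direction. The estimate is a 1.1-fold lower number from compound 2 to compound 3 (0.05 log units; within the scatter) as the expected step. For compound 3 the estimated value is 12000 nM with an expected range from 5000 nM to 30000 nM.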

Compound 3, half-maximal cytotoxic concentration: 7870 nM
Beside the measured number, compound 3's estimate is 1.5-fold (0.18 log units) above it; the range from low to high includes it.
By their numbers in this assay, from the lowest: compounds 3, 1 and 2 (each within the scatter of the next).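

In this assay, the carbon ortho to a 3-chloropropoxy group now holds an amide-bearing substituent, propanoylamino, which brings a hydrogen-bond donor and acceptor that trifluoromethyl lacks, and the readings give a 1.7-fold lower number from compound 2 to compound 3 (0.23 log units; within the scatter) and a 1.1-fold lower number from compound 1 to compound 3 (0.05 log units; within the scatter). Both steps lie within the scatter, as does the earlier step between fluoro and trifluoromethyl, so the three groups at this carbon set no order among compound 1, compound 2 and compound 3, and this change from a small halogen-bearing group to an acylated nitrogen separates nothing here. Nothing available accounts for these level readings or links them to any property of the groups.

Still open, from the compounds shown here alone, is whether an amine, a carboxylic acid or a longer acyl chain at this carbon would read apart from these three compounds in this assay. All three also carry the same 3-chloropropoxy group and the same remaining core, so the share of those parts in the reading cannot be told from them, and a hydroxy group or a shorter chain in place of the 3-chloropropoxy group remains an open comparison.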